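The source may report more compounds than this note shows. Statements on the series, on what has been measured and on what is new or still open speak of the compounds shown alone.

In an ADME assay on MRC5 cells (Homo sapiens) for cytotoxicity, read by fluorescence and resazurin assay, with a stated time of 3 days (on this read-out higher numbers stand for weaker inhibition and lower numbers for stronger inhibition), compound 3 `Cc1cn(C2CCN(Cc3cc(Oc4cc(Cl)cc(Cl)c4)ccn3)CC2)c(=O)[nH]c1=O` stands without a number, as its entry reads "not determined" (no result reported). Its two closest relatives offer only limits. Compound 1 `Cc1cn(C2CCN(Cc3cncc(Oc4cccc(Cl)c4)c3)CC2)c(=O)[nH]c1=O` gives > 64000 nM, which is a limit and not a number. Compound 2 `Cc1cn(C2CCN(Cc3cc(Oc4cccc(Cl)c4)ccn3)CC2)c(=O)[nH]c1=O` gives > 64000 nM, again a limit. Compound 4 `Cc1cn(C2CCN(Cc3cc(Oc4ccccc4)ccn3)CC2)c(=O)[nH]c1=O` carries phenyl in place of 3,5-dichlorophenyl on an oxygen on an aromatic ring. Among the measured compounds shown here, the only guide at hand is the limit of > 64000 nM in this assay, at which 2 of the 3 values shown sit. No measured step sizes this change, so no step beyond the scatter is expected in this assay, in either direction. For compound 4 the expected value is 60000 nM, with an estimated range from 25000 nM to 64000 nM.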

Compound 4, half-maximal inhibitory concentration: > 64000 nM
Compound 4: a limit, no number; the forecaster's own chance of this, stated with the estimate: 80%; middle value at least 1.0-fold (0.02 log units) from the limit.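

Compound 2 and compound 4 both stand at a limit, not a number, in this assay, so no new step can be read between them. The compounds shown leave open whether hydrogen in place of chloro shifts the value in this assay at all.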